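Fluoro in place of tert-butyl: an expected gain

A few compounds are considered here, and "the series" means these few. Any claim that something is new, unique, unknown or untested is made for them only; others in the source may bear on it.

Compound 3 `COc1cc(-c2ccnc3cc(-c4ccc(C(C)(C)C)cc4)nn23)cc(OC)c1OC` carries a tert-butyl group on an aromatic carbon. In a functional assay on HCT-116 cells (Homo sapiens) for inhibition, read by CCK-8 assay, with a stated time of 48 h (a lower number here means a stronger inhibitor, a higher number a weaker inhibitor), compound 3 gives only a limit of the assay, > 10000 nM. Compound 1 `COc1cc(-c2ccnc3cc(-c4ccc(Cl)cc4)nn23)cc(OC)c1OC`, which bears chloro instead, gives 3340 nM in this assay, and the step of an at least 2.9-fold higher number from compound 1 to compound 3 (0.47 log units; beyond the scatter) shows that the tert-butyl group weakens inhibition. Compound 2 `Cn1ccc2cc(-c3cc4nccc(-c5ccc(F)cc5)n4n3)ccc21`, built on a different core but carrying a fluoro group, gives 2160 nM in this assay.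

Compound 4 `COc1cc(-c2ccnc3cc(-c4ccc(F)cc4)nn23)cc(OC)c1OC` differs from compound 3 by fluoro in place of tert-butyl on an aromatic carbon. Because of the step of an at least 2.9-fold higher number from compound 1 to compound 3 (0.47 log units; beyond the scatter) compound 4 is expected to recover potency, by about an at least 2.8-fold lower number from compound 3 to compound 4 (0.45 log units; beyond the scatter). For compound 4 the estimate in this assay is 3500 nM, within a range from 1500 nM to 9000 nM.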

Compound 4, half-maximal inhibitory concentration: 5030 nM
The estimate for compound 4 lay 1.4-fold (0.16 log units) below the measured number, and the stated range covers the measured number.
By their numbers in this assay, from the lowest: compounds 2, 1 and 4 (each within the scatter of the next, the first and the last beyond it). At a limit, above all of these: compound 3.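

In this assay, the change to fluoro gives an at least 1.9-fold lower number from compound 3 to compound 4 (0.29 log units; that floor lies within the scatter), and this floor does not by itself establish a gain. The true size of that step stays open because compound 3 sits at a limit of the assay: the limit of > 10000 nM in this assay, at which 1 of the 4 values shown sits.

With the core held constant, fluoro and chloro on this aromatic carbon cannot be told apart, at a 1.5-fold higher number from compound 1 to compound 4 (0.18 log units; within the scatter). The compounds shown leave open how an amine or a carboxylic acid would fare on this aromatic carbon, and whether any group here can go beyond the level shared by fluoro and chloro.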